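Swapping the ring on the dithiocarbamate nitrogen

This account rests on a few compounds, and the source may have more. Where it says the series, first, only, none or still open, it means among the compounds named here.

The measured compounds:
Compound 1, `CCOC(=O)c1cc(=O)c2cc(CSC(=S)N(C(C)C)C(C)C)ccc2o1`, in a functional assay on MDA-MB-435S cells (Homo sapiens) for antiproliferative activity, read by MTT assay, with a stated time of 72 h (a lower number here means a stronger inhibitor, a higher number a weaker inhibitor), compound 1 gives 8100 nM.
Compound 2, `O=c1cc(CSC(=S)N2CCCCC2)oc2cc(Cl)ccc12`, in this assay compound 2 gives 3000 nM.
Compound 3, `O=c1cc(CSC(=S)N2CCCCC2)oc2ccccc12`, in this assay compound 3 gives > 25000 nM, which is a limit of the assay rather than a number.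

Among the two numbers in hand, compound 2 stands lowest, and compound 1 gives a higher number. The limit seen for compound 3 is the one given as the limit of > 25000 nM in this assay, at which 1 of the 3 values shown sits. Among the measured compounds shown here, the only measured step, an at least 8.3-fold higher number from compound 2 to compound 3 (0.92 log units; beyond the scatter), concerns removal of the chloro group and not the amine ring.

Compound 4, `O=c1cc(CSC(=S)N2CCCC2)oc2cc(Cl)ccc12`, differs from compound 2 in one place: pyrrolidin-1-yl in place of piperidin-1-yl on a thiocarbonyl carbon. For the measured compounds named here, no measured step touches this ring, so the only guide is the size of compound 2 itself, and a change of one atom in a saturated ring is expected to give a step no larger than the scatter, in this assay estimated as a 1.2-fold higher number from compound 2 to compound 4 (0.07 log units; within the scatter). Compound 4 is therefore estimated at 3500 nM, with a range from 1200 nM to 10000 nM.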

Compound 4, half-maximal inhibitory concentration: > 25000 nM
Compound 4 was reported as a limit; the forecaster's own chance of this, stated with the estimate: 10%; middle value at least 7.1-fold (0.85 log units) away from the limit.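

In this assay, the ring on the thiocarbonyl carbon proves to matter: pyrrolidin-1-yl in place of piperidin-1-yl gives an at least 8.3-fold higher number from compound 2 to compound 4 (0.92 log units; beyond the scatter). Until now, only the chloro group had been seen to make such a difference, through an at least 8.3-fold higher number from compound 2 to compound 3 (0.92 log units; beyond the scatter), and with compound 2 this amine ring joins it as a part of the structure that the reading depends on. Compound 4 is reported as a limit, as is compound 3, so each step gives only a minimum size and the two cannot be ranked: the limit of > 25000 nM in this assay, at which 2 of the 4 values shown sit.

As far as these compounds go, it remains open whether only the piperidin-1-yl ring keeps the reading measurable, or whether azepan-1-yl, morpholin-4-yl or an open-chain diethylamino group on the same carbon would too. Whether bromo could stand in for the chloro group is also unknown.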